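The compounds below may be only part of what the source reports. "The series", "measured", "known", "first", "only" and "open" are said of these compounds alone.

Three compounds share one core and differ only at the far end of a saturated chain that runs from a sulfonyl sulfur. Compound 1 is `CCCCCCCCCCS(=O)(=O)/C=C/c1ccc(O)c(O)c1`, compound 2 is `CCCCCCCCS(=O)(=O)/C=C/c1ccc(O)c(O)c1` and compound 3 is `O=S(=O)(/C=C/c1ccc(O)c(O)c1)CCCCCCCCO`. In a functional assay, read by fluorescence and spectrophotometry, with a stated time of 1 h (a lower number here means that less compound is needed, a higher number that more compound is needed for the effect), compound 1 gives 6800 nM, compound 2 gives 6400 nM and compound 3 gives 6700 nM. These three numbers cannot be told apart: the step of a 1.0-fold lower number from compound 1 to compound 3 (0.01 log units; within the scatter) and the step of a 1.0-fold higher number from compound 2 to compound 3 (0.02 log units; within the scatter) both stay within the scatter, as does a 1.1-fold lower number from compound 1 to compound 2 (0.03 log units; within the scatter). Compound 3 therefore stands level with its two neighbours.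

Compound 4 is `O=S(=O)(/C=C/c1ccc(O)c(O)c1)CCCCCCCCCCCO`. It differs from compound 3 in one place: 3-hydroxypropyl in place of hydroxy on a saturated chain carbon, eight bonds along the chain from a sulfonyl sulfur. Within the data shown here, every change tried at this place so far, whether ethyl, hydrogen or hydroxy, left this assay unmoved beyond the scatter. Lengthening the chain end once more is expected to do the same, so the expected step is no change at the digits printed from compound 3 to compound 4 (within the scatter), that is none beyond the scatter. Compound 4 is thus estimated at 6700 nM, with a range from 3500 nM to 13000 nM.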

Compound 4, half-maximal effective concentration: 22600 nM
The estimate for compound 4 lay 3.4-fold (0.53 log units) below the measured number; the measured number lies above the stated range.
By their numbers in this assay, from the lowest: compounds 2, 3 and 1 (each within the scatter of the next); then compound 4.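

In this assay this position turns out not to be indifferent: 3-hydroxypropyl in place of hydroxy gives a 3.4-fold higher number from compound 3 to compound 4 (0.53 log units; beyond the scatter), and the other two neighbours tell the same story, with a 3.5-fold higher number from compound 2 to compound 4 (0.55 log units; beyond the scatter) and a 3.3-fold higher number from compound 1 to compound 4 (0.52 log units; beyond the scatter). The level stretch therefore has an end, and it is not set by the hydroxy alone or by chain length alone, since compound 3 carries the hydroxy and compound 1 has the longer chain without it, and both stay level with compound 2, while only compound 4 combines the two. No measurement shown explains the rise.

On these data alone, it remains open whether a longer chain ending in plain hydrogen would move the number too, or what an amine or a carboxylic acid would do at the chain end in place of hydroxy. Also open, as far as these compounds go, is whether a still longer chain ending in hydroxy would raise the number further.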